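The compounds below may be only part of what the source reports. "The series", "measured", "known", "first", "only" and "open" are said of these compounds alone.

Compound 1 `Cc1ccc(-c2ccc(C(=O)N[C@H](c3nc(C)c(CO)s3)[C@@H]3CCCCN3)[nH]2)cc1F` is the reference point of this pair. Within the data shown here, in a toxicity assay on TZM cells (Homo sapiens) for cytotoxicity, read by XTT assay, with a stated time of 3 days (a higher number here means that more compound is tolerated, a lower number that less compound is tolerated), compound 1 gives 18000 nM, a number that stands within the scatter of the only other value at hand. Its counterpart compound 2 `Cc1ccc(-c2ccc(C(=O)N[C@@H](c3nc(C)c(CO)s3)[C@@H]3CCCCN3)[nH]2)cc1F` gives 19200 nM in this assay; the step of a 1.1-fold higher number from compound 1 to compound 2 (0.03 log units; within the scatter) rests on the fact that compounds 1 and 2 differ only in the configuration as drawn and shows that the configuration at the saturated chain carbon does not shift the tolerated concentration.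

Compound 3 `Cc1ccc(-c2ccc(C(=O)N[C@H](c3nc(C)c(CCO)s3)[C@@H]3CCCCN3)[nH]2)cc1F` differs from compound 1 by hydroxymethyl in place of hydroxy on a saturated chain carbon bound to an aromatic carbon, so that the hydroxymethyl on the thiazole becomes a 2-hydroxyethyl. Among the measured compounds shown here, no measured step covers this homologation; the single step available concerns configuration alone and sat within the scatter, so it gives no direction. Expected for compound 3 in this assay is a step of no change at the digits printed from compound 1 to compound 3 (within the scatter), none beyond the scatter. The estimate for compound 3 is 18000 nM, range 9000 nM to 36000 nM.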

Compound 3, half-maximal cytotoxic concentration: 28800 nM
Compound 3: the middle estimate sits 1.6-fold (0.20 log units) below what was measured; the measured number falls inside the stated range.
By their numbers in this assay, from the lowest: compounds 1, 2 and 3 (each within the scatter of the next).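

Going from hydroxymethyl to 2-hydroxyethyl gives a 1.6-fold higher number from compound 1 to compound 3 (0.20 log units; within the scatter) in this assay, and this is the first change in these notes that alters the atoms rather than the configuration as drawn. At this place, on a saturated chain carbon bound to an aromatic carbon, hydroxymethyl in place of hydroxy therefore gives no step beyond the scatter, so the two chain lengths cannot be told apart here. No available evidence bears on this homologation, so nothing can be said about what lies behind the size of the step.

From the compounds shown here alone, it remains open whether a longer chain such as 3-hydroxypropyl, or an amine or a carboxylic acid in place of the hydroxy, would stay within the scatter of compound 1. Also open, going by these compounds, is whether the configuration at the saturated chain carbon stays without effect once 2-hydroxyethyl is present.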